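Methyl for Fluoro on the Fused Ring of Compound 1

The source may hold more compounds than are shown below. What is called first, only, known or untested is meant among the compounds shown, and "the series" means these compounds.

Compound 1 `Cc1cc(Nc2nc(NCc3ccc(F)cc3F)nc3ccc(F)cc23)n[nH]1`: 44 nM
Compound 2 `Fc1ccc(CNc2nc(Nc3cc(C4CC4)[nH]n3)c3cc(F)ccc3n2)c(F)c1`: 59 nM

In an assay for inhibition of high affinity nerve growth factor receptor (Homo sapiens), read by HTRF, with a stated time of 30 min, in the presence of a further agent that is not named here (a higher number here means a weaker inhibitor, a lower number a stronger inhibitor), compound 1 gives 44 nM and compound 2 gives 59 nM. Compound 1 stands lowest of the two numbers; its nearest neighbour is compound 2, with a 1.3-fold higher number from compound 1 to compound 2 (0.13 log units; within the scatter), a step within the scatter. Compound 3 `Cc1ccc2nc(NCc3ccc(F)cc3F)nc(Nc3cc(C)[nH]n3)c2c1` differs from compound 1 by methyl in place of fluoro on an aromatic carbon. For the measured compounds named here, no measured step changes that same carbon; the only recorded step, a 1.3-fold higher number from compound 1 to compound 2 (0.13 log units; within the scatter), concerns a different change and lies within the scatter. Nothing therefore points to a shift beyond the scatter in this assay. Compound 3 is expected to give 50 nM (range 20 nM to 130 nM), an estimated 1.1-fold higher number from compound 1 to compound 3 (0.06 log units; within the scatter).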

Compound 3, half-maximal inhibitory concentration: 110 nM
For compound 3 the middle estimate is 2.2-fold (0.34 log units) below the measured one; the range from low to high includes it.
By their numbers in this assay, from the lowest: compounds 1, 2 and 3 (each within the scatter of the next, the first and the last beyond it).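

In this assay, methyl in place of fluoro on this aromatic carbon gives a 2.5-fold higher number from compound 1 to compound 3 (0.40 log units; beyond the scatter) and so moves the number beyond the scatter, a modest step. The earlier step, cyclopropyl in place of methyl at another place, had stayed within the scatter, so this carbon is the first place shown where one change registers. Nothing measured here bears on the reason for this shift. From the compounds shown here alone, whether a chloro group, a methoxy group or an amine on this carbon would track fluoro or methyl remains open. So does whether the same exchange would give a similar step on compound 2.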